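Replacing diethylcarbamoyl: notes on compound 3 and compound 4

A few compounds are considered here, and "the series" means these few. Any claim that something is new, unique, unknown or untested is made for them only; others in the source may bear on it.

Measured so far:
- compound 1 `COc1ccc(-c2nc(CN)sc2-c2ccc(OC)cc2)cc1` with 7.7 uM
- compound 2 `COc1ccc(-c2nc(CNC(=O)N3CCOCC3)sc2-c2ccc(OC)cc2)cc1` with 12 uM
- compound 3 `CCN(CC)C(=O)c1nc(-c2ccc(OC)cc2)c(-c2ccc(OC)cc2)s1` with 14 uM

In a functional assay (aorta) with Rattus norvegicus as the target (on this read-out lower numbers stand for an effect already at smaller amounts and higher numbers for an effect only at larger amounts of compound), compound 3 gives 14 uM and stands within the scatter of both other compounds. The next change yields compound 4 `CCOC(=O)/C(C#N)=C/c1nc(-c2ccc(OC)cc2)c(-c2ccc(OC)cc2)s1` with 2-cyano-2-(ethoxycarbonyl)ethenyl in place of diethylcarbamoyl on an aromatic carbon, counted as 2-cyano-2-(ethoxycarbonyl)ethenyl in place of diethylcarbamoyl on an aromatic carbon and placed next to the ring nitrogen and next to the ring sulfur.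

Two measured steps exchange the group on that same carbon, a 1.8-fold higher number from compound 1 to compound 3 (0.26 log units; within the scatter) and a 1.2-fold higher number from compound 2 to compound 3 (0.07 log units; within the scatter), and the remaining step is a 1.6-fold higher number from compound 1 to compound 2 (0.19 log units; within the scatter) and also stays within the scatter. Among the measured compounds shown here, no measured compound carries the entering group, so the evidence is thin and the range is kept wide. Three different groups on this carbon have shown no step beyond the scatter, and none is expected here in this assay either. The expected step is a 1.2-fold lower number from compound 3 to compound 4 (0.07 log units; within the scatter) and no more than that. The estimate for compound 4 is 12 uM with an expected range from 4 uM to 35 uM.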

Compound 4, concentration for half-maximal effect: > 100 uM
Compound 4: a limit, no number; the forecaster's own chance of this, stated with the estimate: 15%; middle value at least 8.3-fold (0.92 log units) away from the limit.
By their numbers in this assay, from the lowest: compounds 1, 2 and 3 (each within the scatter of the next). At a limit, above all of these: compound 4.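

In this assay compound 4 gives > 100 uM, which is a limit of the assay and not a number. The aromatic carbon next to the ring nitrogen and next to the ring sulfur, where aminomethyl, (((morpholin-4-yl)carbonyl)amino)methyl and diethylcarbamoyl stay within the scatter of one another, does respond to the group it carries, as 2-cyano-2-(ethoxycarbonyl)ethenyl brings an at least 7.1-fold higher number from compound 3 to compound 4 (0.85 log units; beyond the scatter), an at least 8.3-fold higher number from compound 2 to compound 4 (0.92 log units; beyond the scatter) and an at least 12-fold higher number from compound 1 to compound 4 (1.11 log units; beyond the scatter). All three steps rest on one reading and give only a lower bound on the change: the limit of > 100 uM in this assay, at which 1 of the 4 values shown sits.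

The compounds shown do not separate the ethoxycarbonyl, the nitrile and the ethenyl link from one another. On these data alone, a carboxylic acid in place of the ethyl ester, or an ethenyl chain without the nitrile, would show whether one part carries the step, and the true size of the step remains unknown.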